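A few compounds are considered here, and "the series" means these few. Any claim that something is new, unique, unknown or untested is made for them only; others in the source may bear on it.

Measured so far: compound 1, `CCCC/C(=C\C=C\C(=O)N[C@H](C)CCCc1cccnc1)c1ccc(OC)cc1`, in an assay (Canis lupus familiaris) for binding affinity to platelet-activating factor receptor (Homo sapiens), read by radioligand binding (on this read-out higher numbers stand for weaker inhibition and lower numbers for stronger inhibition), gives 14 nM; compound 2, `COc1cccc(C(=C/C=C/C(=O)NCCCCc2cccnc2)c2cccc(OC)c2)c1`, gives 2 nM; compound 3, `CCC/C(=C\C=C\C(=O)N[C@H](C)CCCc1cccnc1)c1ccc(OC)cc1`, gives 50 nM.

Compound 2 stands lowest of the three, and its gaps to compound 1 and to compound 3 are both beyond the scatter. How the core of compound 2 differs from the core of compound 3 is not broken down here.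

One step is measured between compounds that differ in one place: a 3.6-fold lower number from compound 3 to compound 1 (0.55 log units; beyond the scatter). The change is methyl in place of hydrogen on a saturated chain carbon, three bonds along the chain from a double-bonded chain carbon.

Compound 4, `COc1cccc(C(=C/C=C/C(=O)N[C@H](C)CCCc2cccnc2)c2cccc(OC)c2)c1`, has not yet been measured in this assay. It differs from compound 2 by methyl in place of hydrogen on a saturated chain carbon bound to an amide-type nitrogen and a saturated chain carbon. Among the compounds with values here, this is the same kind of change as the one from compound 3 to compound 1, but not the same: there the methyl enters on a saturated chain carbon, three bonds along the chain from a double-bonded chain carbon, whereas here it enters on a saturated chain carbon bound to an amide-type nitrogen and a saturated chain carbon. The earlier step was modest and lowered the number; compound 2 already gives a low number. The expectation for compound 4 rests on that single earlier step and on the starting value of compound 2 (2 nM), so a small step is expected: a 1.3-fold lower number from compound 2 to compound 4 (0.12 log units; within the scatter). Compound 4 is therefore estimated at 1.5 nM, with a likely range from 0.5 nM to 6 nM.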

Compound 4, half-maximal inhibitory concentration: 35 nM
Compound 4: middle estimate off by 23-fold (1.37 log units), on the low side, and the stated range ends below it.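

In this assay, methyl in place of hydrogen on a saturated chain carbon bound to an amide-type nitrogen and a saturated chain carbon, which turns 4-(pyridin-3-yl)butyl into 1-methyl-4-(pyridin-3-yl)butyl, gives an 18-fold higher number from compound 2 to compound 4 (1.24 log units; beyond the scatter). Set beside the earlier methyl step, this one runs the opposite way, so neither the direction nor the size of a methyl step could be carried over from one core to the other here: the same change on two cores in this assay, a 3.6-fold lower number (0.55 log units; beyond the scatter) from compound 3 to compound 1 and an 18-fold higher number (1.24 log units; beyond the scatter) from compound 2 to compound 4, 63-fold (1.80 log units) apart, beyond the scatter of two such steps What this does not show is the source of the gap, since the two methyl groups enter at different places as well as on different cores, and a single pair on each side cannot separate place from core or give a rule for the wider series.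

The compounds shown leave open whether the same methyl, on the carbon bound to the amide-type nitrogen, would also raise the number when that carbon's chain is paired with the core of compound 3. They also leave open whether an ethyl or a hydroxymethyl group on that carbon would follow the methyl group.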